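Swapping a Bromophenyl for a Nitrophenyl: Expected Cytotoxicity

The source may hold more compounds than are shown below. What is called first, only, known or untested is meant among the compounds shown, and "the series" means these compounds.

Of the compounds shown here, three built on one shared core have been tested so far. Compound 1 `O=C(CSc1nnc(-c2ccncc2)o1)N/N=C/c1ccc(Cl)cc1`, compound 2 `O=C(CSc1nnc(-c2ccncc2)o1)N/N=C/c1ccc(Br)cc1` and compound 3 `O=C(CSc1nnc(-c2ccncc2)o1)N/N=C/c1cccc(F)c1` differ only in the substituted phenyl ring attached to a carbon with a double bond to nitrogen. In an ADME assay on NIH3T3 cells (Mus musculus) for cytotoxicity, read by MTT assay, with a stated time of 24 h (a higher number here means a weaker inhibitor, a lower number a stronger inhibitor), compound 1 gives 181000 nM. Compound 2 gives 169000 nM in this assay, and compound 3 gives 205000 nM. Compound 2 sits inside the scatter of both of its neighbours: the step of a 1.1-fold lower number from compound 1 to compound 2 (0.03 log units; within the scatter) and the step of a 1.2-fold higher number from compound 2 to compound 3 (0.08 log units; within the scatter) are each too small to count as a real change, and the same holds for a 1.1-fold higher number from compound 1 to compound 3 (0.05 log units; within the scatter).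

Compound 4 `O=C(CSc1nnc(-c2ccncc2)o1)N/N=C/c1ccccc1[N+](=O)[O-]` has not yet been measured. Relative to compound 2 the change is 2-nitrophenyl in place of 4-bromophenyl on a carbon with a double bond to nitrogen. Going by the values given here, none of the measured steps involves a nitro group, so the only guidance is that exchanging one halogenated phenyl ring for another, whether bromo for chloro or 3-fluorophenyl for 4-bromophenyl, left this assay unmoved beyond the scatter. On that basis the step is expected to be small as well: a 1.1-fold higher number from compound 2 to compound 4 (0.03 log units; within the scatter). Compound 4 is therefore estimated at 180000 nM in this assay, with a likely range from 90000 nM to 360000 nM.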

Compound 4, half-maximal inhibitory concentration: 214000 nM
Compound 4: middle estimate off by 1.2-fold (0.08 log units), on the low side, within the range that was stated.
By their numbers in this assay, from the lowest: compounds 2, 1, 3 and 4 (each within the scatter of the next).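

At the carbon with a double bond to nitrogen, the ring can now carry something other than a halogen: 2-nitrophenyl brings in nitrogen and oxygen atoms and 2 hydrogen-bond acceptors, where 4-bromophenyl has 0. Even so, in this assay all three new comparisons stay within the scatter (a 1.3-fold higher number from compound 2 to compound 4 (0.10 log units; within the scatter); a 1.2-fold higher number from compound 1 to compound 4 (0.07 log units; within the scatter); a 1.0-fold higher number from compound 3 to compound 4 (0.02 log units; within the scatter)), so this first change away from a halogen leaves compound 4 indistinguishable from compounds 1, 2 and 3, and the four compounds form one group with no order among them. Nothing available explains why the number stays put, and no outside measurement bears on this result.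

All four compounds shown carry a phenyl ring with a single substituent on the same shared core, so it remains open whether this flat response would hold for a ring bearing an amine, a carboxylic acid or a longer chain. On these data alone, it is also open whether changing the shared core itself, rather than this ring, would move the number beyond the scatter.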